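The source may report more compounds than this note shows. Statements on the series, on what has been measured and on what is new or still open speak of the compounds shown alone.

Measured so far in a physicochemical assay for lipophilicity, at pH 7.4; on this read-out lower numbers stand for lower lipophilicity and higher numbers for higher lipophilicity:
- compound 1 `Cc1cnn(-c2ccncc2N2CCC(C(=O)N(C)C)CC2)c1`: 1.6
- compound 2 `CN(C)C(=O)C1CCN(c2cnccc2-n2cc(Br)cn2)CC1`: 2.1

Of these two, compound 2 stands higher, at 2.1. The next structure is compound 3 `CN(C)C(=O)C1CCN(c2cnccc2-n2cc(C(F)(F)F)cn2)CC1`, with trifluoromethyl in place of bromo on an aromatic carbon. For the measured compounds named here, no measured compound carries trifluoromethyl. Going by the values given here, one measured step bears on the change: a number 0.50 log units higher from compound 1 to compound 2 (beyond the scatter), with bromo in place of methyl on an aromatic carbon. Given that modest step, a small upward step in this assay is expected: a number 0.20 log units higher from compound 2 to compound 3 (within the scatter). The estimate for compound 3 is 2.3, with an expected range of 1.9 to 2.7.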

Compound 3, distribution coefficient: 2.1
Estimate against measurement, compound 3: 0.20 log units above, and the stated range covers the measured number.
By their numbers in this assay, from the lowest: compound 1; then compounds 2 and 3 (each within the scatter of the next).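

In this assay, trifluoromethyl and bromo on this aromatic carbon of the five-membered ring cannot be told apart (no change at the digits printed from compound 2 to compound 3 (within the scatter)). The gain over methyl is therefore not specific to bromo, since trifluoromethyl also gives a step beyond the scatter (a number 0.50 log units higher from compound 1 to compound 3 (beyond the scatter)). Nothing available offers a reason for this match between the two groups.

Still open, from the compounds shown here alone, is how an amine, a carboxylic acid or a nitrile on this carbon would compare with these three compounds. Also open, going by these compounds, is whether bromo and trifluoromethyl would match on any other core.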